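Swapping a Phenyl for Methoxy on the Sulfonyl Ring

The source may hold more compounds than are shown below. What is called first, only, known or untested is meant among the compounds shown, and "the series" means these compounds.

Compound 3 `CC1CCN(C2CCN(S(=O)(=O)c3cccc(-c4ccccc4)c3)CC2)CC1` gives 2 nM in a functional assay on DLD-1 cells (Homo sapiens) for antiproliferative activity, read by CellTiter-Glo, with a stated time of 72 h (a lower number here means a stronger inhibitor, a higher number a weaker inhibitor), the lowest of the two numbers in this set. Compound 2 `Cc1ccc(S(=O)(=O)N2CCC(N3CCC(C)CC3)CC2)cc1C` gives 24 nM; no single-point step links it to compound 3, so the two values simply stand as shown. Compound 1 `CCc1ccc(S(=O)(=O)N2CCC(N3CCC(C)CC3)CC2)cc1` reaches only a limit of the assay, > 5000 nM (the limit of > 5000 nM in this assay, at which 1 of the 3 values shown sits). For the measured compounds named here, the one measured step, an at least 200-fold lower number from compound 1 to compound 2 (2.31 log units; beyond the scatter), shows that changing the groups on the ring attached to the sulfonyl sulfur can move the number a great deal.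

Compound 4 `COc1cccc(S(=O)(=O)N2CCC(N3CCC(C)CC3)CC2)c1` differs from compound 3 as follows: methoxy in place of phenyl on an aromatic carbon. This change sits on the same ring as the measured step, so a large movement is plausible, and since compound 3 holds the lowest value, the step is expected to go toward a higher number. For compound 4 the expected step is a 75-fold higher number from compound 3 to compound 4 (1.88 log units; beyond the scatter). Compound 4 is therefore estimated at 150 nM, with a range from 20 nM to 2000 nM.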

Compound 4, half-maximal inhibitory concentration: > 5000 nM
Compound 4 ended at the assay's limit; the forecaster's own chance of this, stated with the estimate: 15%; middle value at least 33-fold (1.52 log units) from the limit.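

Methoxy in place of phenyl on this aromatic carbon gives an at least 2500-fold higher number from compound 3 to compound 4 (3.39 log units; beyond the scatter), so at this place on the ring, the low number of compound 3 does not survive the loss of phenyl. The 3-methoxyphenyl group also compares poorly with 3,4-dimethylphenyl, with an at least 200-fold higher number from compound 2 to compound 4 (2.31 log units; beyond the scatter), so simply having a group at this place on the ring does not keep the number low. In this assay compound 4 gives a limit and not a number, and its step from compound 1 cannot be read: the limit of > 5000 nM in this assay, at which 2 of the 4 values shown sit.

The compounds shown do not separate the loss of the aromatic ring from the arrival of the methoxy group. As far as these compounds go, whether a cyclohexyl ring or a pyridine ring at this place would restore a low number remains open.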